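A few compounds are considered here, and "the series" means these few. Any claim that something is new, unique, unknown or untested is made for them only; others in the source may bear on it.

In a functional assay on CCRF-CEM cells (Homo sapiens), read by MTT assay, with a stated time of 72 h (a lower number here means a stronger inhibitor, a higher number a weaker inhibitor), compound 1, whose structure is `COc1ncnc2c1c(-c1cccs1)cn2[C@@H]1O[C@H](CO)[C@@H](O)[C@H]1O`, gives 90 nM. Among the three measured compounds this places compound 1 second highest: compound 3, `COc1ncnc2c1c(-c1ccoc1)cn2[C@@H]1O[C@H](CO)[C@@H](O)[C@H]1O`, gives 110 nM, and the two values sit within the usual scatter of each other (a 1.2-fold higher number from compound 1 to compound 3 (0.09 log units; within the scatter)). Compound 2, `COc1ncnc2c1c(-c1ccco1)cn2[C@@H]1O[C@H](CO)[C@@H](O)[C@H]1O`, gives 20 nM, and the step of a 4.5-fold lower number from compound 1 to compound 2 (0.65 log units; beyond the scatter) lies beyond the scatter, as does a 5.5-fold higher number from compound 2 to compound 3 (0.74 log units; beyond the scatter).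

Compound 4, `CSc1ncnc2c1c(-c1cccs1)cn2[C@@H]1O[C@H](CO)[C@@H](O)[C@H]1O`, differs from compound 1 at a different position: methylsulfanyl in place of methoxy on an aromatic carbon. Every measured step changes the ring attached to the shared core, while the methoxy group stays in place in compounds 1, 2 and 3. Among the measured compounds shown here, none of the measured steps therefore bears directly on the change to compound 4, and the data give no basis for expecting a shift beyond the scatter in this assay. On these data alone, the expected step is no change at the digits printed from compound 1 to compound 4 (within the scatter), with a wide range to reflect that the change is untested. Compound 4 is estimated at 90 nM, between 30 nM and 270 nM.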

Compound 4, half-maximal inhibitory concentration: > 20000 nM
Compound 4: only a limit was reported (the forecaster's own chance of this, stated with the estimate: 5%); middle value at least 220-fold (2.34 log units) from the limit.
By their numbers in this assay, from the lowest: compound 2; then compounds 1 and 3 (each within the scatter of the next). At a limit, above all of these: compound 4.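

In this assay, putting methylsulfanyl in place of methoxy on the aromatic carbon next to the ring nitrogen, with the thiophen-2-yl ring left unchanged, gives an at least 220-fold higher number from compound 1 to compound 4 (2.34 log units; beyond the scatter). The result for compound 4 is a limit and not a measured number, so the true size of this step stays unknown: the limit of > 20000 nM in this assay, at which 1 of the 4 values shown sits. The ring changes among compounds 1, 2 and 3 reach no further than a 5.5-fold higher number from compound 2 to compound 3 (0.74 log units; beyond the scatter), so exchanging one oxygen for one sulfur at this position moves the number far more than any ring change shown.

The compounds shown leave open whether an amine or a longer chain such as ethoxy on this carbon would keep the number close to that of compound 1. They also leave open whether methylsulfanyl would have the same effect alongside the furan-2-yl ring of compound 2, and they give no reason for the step.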